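Tert-butyl on the benzyl of compound 2

The source may report more compounds than this note shows. Statements on the series, on what has been measured and on what is new or still open speak of the compounds shown alone.

Measured in a functional assay on MDA-MB-231 cells (Homo sapiens) for cytotoxicity, read by MTT assay, with a stated time of 72 h; on this read-out lower numbers stand for stronger inhibition and higher numbers for weaker inhibition:
- compound 1 `CCN(CC)Cc1ccc2nc(NC(=O)N/N=C/c3cn(Cc4ccc(C(C)(C)C)cc4)c4ccccc34)sc2c1` gives 2120 nM
- compound 2 `CC1CCN(Cc2ccc3nc(NC(=O)N/N=C/c4cn(Cc5ccccc5)c5ccccc45)sc3c2)CC1` gives 2850 nM

Compound 2 stands within the scatter of compound 1, so these two numbers do not separate. Compound 3 `CC1CCN(Cc2ccc3nc(NC(=O)N/N=C/c4cn(Cc5ccc(C(C)(C)C)cc5)c5ccccc45)sc3c2)CC1` is compound 2 with tert-butyl in place of hydrogen on an aromatic carbon, which turns benzyl into 4-(tert-butyl)benzyl (tert-butyl in place of hydrogen on an aromatic carbon). Within the data shown here, no step between measured compounds isolates this change. Compound 1 also carries 4-(tert-butyl)benzyl and gives 2120 nM, which is only a loose guide. No step beyond the scatter is expected in this assay, and no firm direction can be stated. The estimate amounts to an expected 1.2-fold lower number from compound 2 to compound 3 (0.09 log units; within the scatter). For compound 3 the expected value is 2300 nM, with an estimated range from 800 nM to 6500 nM.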

Compound 3, half-maximal inhibitory concentration: 3880 nM
For compound 3 the middle estimate is 1.7-fold (0.23 log units) below the measured one; measured number inside the range.
By their numbers in this assay, from the lowest: compounds 1, 2 and 3 (each within the scatter of the next).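

In this assay, tert-butyl in place of hydrogen on the benzyl ring, para to a large group, gives a 1.4-fold higher number from compound 2 to compound 3 (0.13 log units; within the scatter), so this change on the 4-methylpiperidin-1-yl compound does not separate from the scatter. With 4-(tert-butyl)benzyl held constant, 4-methylpiperidin-1-yl in place of diethylamino gives a 1.8-fold higher number from compound 1 to compound 3 (0.26 log units; within the scatter), so this exchange of amines does not separate the two compounds either. No measurement in hand accounts for these results.

From the compounds shown here alone, it remains open whether a methoxy group, a carboxylic acid or a primary amine at the same place on the benzyl ring would give a step beyond the scatter. Also open, going by these compounds, is whether tert-butyl gives a similar step when diethylamino replaces 4-methylpiperidin-1-yl.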